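Replacing (2-Fluorophenyl)amino with (2-(1H-Indol-3-yl)ethyl)sulfanyl

A few compounds are considered here, and "the series" means these few. Any claim that something is new, unique, unknown or untested is made for them only; others in the source may bear on it.

In a functional assay on SK-OV-3 cells (Homo sapiens) for inhibition, read by crystal violet staining, with a stated time of 72 h (a lower number here means a stronger inhibitor, a higher number a weaker inhibitor), compound 1 `COc1cc(CNC(=O)CCCC/C=C/C(C)C)ccc1OCc1nnc(Nc2ccc([N+](=O)[O-])cc2)o1` gives 6400 nM. Compound 2 `COc1cc(CNC(=O)CCCC/C=C/C(C)C)ccc1OCc1nnc(Nc2ccccc2F)o1` differs only at a nitrogen on an aromatic ring, and in this assay compound 2 gives 12500 nM, the upper end of the two numbers shown, although the step of a 2.0-fold higher number from compound 1 to compound 2 (0.29 log units; within the scatter) lies within the scatter. Compound 3 `COc1cc(CNC(=O)CCCC/C=C/C(C)C)ccc1OCc1nnc(SCCc2c[nH]c3ccccc23)o1` carries (2-(1H-indol-3-yl)ethyl)sulfanyl in place of (2-fluorophenyl)amino on an aromatic carbon. Within the data shown here, only that single step touches this position, and it was small, so nothing measured points to a direction. The estimate for compound 3 is therefore 10000 nM, with a range from 2500 nM to 40000 nM, the expected step of a 1.3-fold lower number from compound 2 to compound 3 (0.10 log units; within the scatter) being none beyond the scatter.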

Compound 3, half-maximal inhibitory concentration: 31400 nM
Beside the measured number, compound 3's estimate is 3.1-fold (0.50 log units) below it; the measured number falls inside the stated range.
By their numbers in this assay, from the lowest: compounds 1 and 2 (each within the scatter of the next); then compound 3.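

In this assay, this position now shows a change beyond the scatter, with a 2.5-fold higher number from compound 2 to compound 3 (0.40 log units; beyond the scatter) and a 4.9-fold higher number from compound 1 to compound 3 (0.69 log units; beyond the scatter), both modest, whereas the earlier exchange of (4-nitrophenyl)amino for (2-fluorophenyl)amino stayed within it. On this aromatic carbon, (2-(1H-indol-3-yl)ethyl)sulfanyl therefore makes a weaker inhibitor than either amino group. Nothing measured here explains the shift. The compounds shown leave open whether the sulfur link or the indole carries the change, since (2-(1H-indol-3-yl)ethyl)amino and a simple methylsulfanyl group are not among them.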